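This account rests on a few compounds, and the source may have more. Where it says the series, first, only, none or still open, it means among the compounds named here.

Three measured compounds share one core. In a physicochemical assay for lipophilicity (a lower number here means a more polar compound, a higher number a more lipophilic compound), compound 1 `Cc1cc(=O)[nH]c2cc(NC(=O)c3c(Br)cccc3Br)ccc12` gives 1.75. Compound 2 `Cc1cc(=O)[nH]c2cc(NC(=O)/C=C/c3ccccc3)ccc12` gives 1.69 in this assay, and compound 3 `Cc1ccc(C(=O)Nc2ccc3c(C)cc(=O)[nH]c3c2)cc1` gives 1.67 in this assay. The gap from compound 3 to compound 2 and the gap from compound 3 to compound 1 both lie within the usual scatter of repeated measurements, so none of the three can be set apart from the others on these numbers. Among the measured compounds shown here, no two of them differ in only one place, so no measured step is available as a guide.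

Compound 4 `Cc1ccccc1C(=O)Nc1ccc2c(C)cc(=O)[nH]c2c1` has not been measured. It differs from compound 3 in one place: 2-methylphenyl in place of 4-methylphenyl on a carbonyl carbon. What leaves and what enters match in atom count, in the single six-membered aromatic ring of carbon only, in hydrogen-bond donors and acceptors, and in charge. For the measured compounds named here, with nothing among the measured compounds showing the size of such a change, the expected step of a number 0.07 log units lower from compound 3 to compound 4 (within the scatter) is estimated to stay within the scatter in this assay, with no direction favoured beyond it. Compound 4 is therefore estimated at 1.6, with a range from 1.35 to 1.9.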

Compound 4, partition coefficient: 1.71
Beside the measured number, compound 4's estimate is 0.11 log units below it; measured number inside the range.
By their numbers in this assay, from the lowest: compounds 3, 2, 4 and 1 (each within the scatter of the next).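

Among the compounds shown here, this is the first measured step between two compounds that differ in one place, and it falls on a carbonyl carbon whose other neighbour is an amide-type nitrogen. In this assay, 2-methylphenyl in place of 4-methylphenyl gives a number 0.04 log units higher from compound 3 to compound 4 (within the scatter), so this exchange, which keeps the same atoms, does not set the two compounds apart. Nothing among the data shown offers an explanation for this result.

The compounds shown leave open whether 3-methylphenyl at this place would also stay within the scatter of compound 3. They also leave open what would happen if the methyl on the ring gave way to a longer chain such as propyl, to an amine or to a carboxylic acid.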